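A Chlorophenyl Amide Replaces the Methylsulfonyl Group

The source may report more compounds than this note shows. Statements on the series, on what has been measured and on what is new or still open speak of the compounds shown alone.

Compound 1 `O=C(Nc1ccc(Cl)c(-c2nnc3c(Cl)cccn23)c1)c1ccc(C(F)(F)F)cc1Cl` gives > 100000 nM in a functional assay on HeLa cells (Homo sapiens) for antiproliferative activity, read by MTT assay, with a stated time of 72 h (a higher number here means a weaker inhibitor, a lower number a stronger inhibitor), which is a limit of the assay rather than a number. Compound 2 `CS(=O)(=O)c1ccc(C(=O)Nc2ccc(Cl)c(-c3nnc4c(Cl)cccn34)c2)cc1` likewise gives > 100000 nM in this assay, again a limit. Going by the values given here, compound 3 `CS(=O)(=O)c1cccc(C(=O)Nc2ccc(Cl)c(-c3nnc4c(Cl)cccn34)c2)c1` gives 86400 nM in this assay, the only number among the three values shown. Among the compounds with values here, the one measured step, an at least 1.1-fold lower number from compound 2 to compound 3 (0.06 log units; that floor lies within the scatter), stays within the scatter. Compound 4 `O=C(Nc1ccc(Cl)c(-c2nnc3c(Cl)cccn23)c1)c1ccccc1Cl` differs from compound 3 in that (2-chlorophenyl in place of 3-(methylsulfonyl)phenyl on a carbonyl carbon). Within the data shown here, no measured step bears directly on this change; what weighs most is the limit of > 100000 nM in this assay, at which 2 of the 3 values shown sit. Compound 4 is therefore expected to sit near that limit, a step of about a 1.2-fold higher number from compound 3 to compound 4 (0.06 log units; within the scatter). The estimate for compound 4 is 100000 nM, with a range from 30000 nM to 300000 nM.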

Compound 4, half-maximal inhibitory concentration: > 100000 nM
Compound 4: a limit, no number; the forecaster's own chance of this, stated with the estimate: 60%; the middle value lies on the limit itself.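

In this assay, 2-chlorophenyl in place of 3-(methylsulfonyl)phenyl on a carbonyl carbon gives an at least 1.1-fold higher number from compound 3 to compound 4 (0.06 log units; that floor lies within the scatter), so this step does not separate the two groups. Compound 4 gives > 100000 nM, which is a limit of the assay and not a number. The steps from compound 2 and from compound 1 to compound 4 cannot be read, and the set now rests mostly on one limit: the limit of > 100000 nM in this assay, at which 3 of the 4 values shown sit.

The compounds shown leave open whether any group at this place gives a value clear of that limit. An amine or a carboxylic acid in place of the chlorine of compound 4 would bear on that.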